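The source may hold more compounds than are shown below. What is called first, only, known or untested is meant among the compounds shown, and "the series" means these compounds.

Compound 1 `CCCCc1nc(C(C)C)c(CC(=O)OC)c(=O)n1Cc1ccc(-c2ccccc2-c2noc(=O)[nH]2)cc1`: in an ADME assay on microsomes from liver (Homo sapiens) for metabolic stability, with a stated time of 30 min (on this read-out higher numbers stand for a more stable compound and lower numbers for a less stable compound), compound 1 gives 10.5%.
Compound 2 `CCCCc1nc(C(C)C)c(CC(=O)OC2CCCCC2)c(=O)n1Cc1ccc(-c2ccccc2-c2noc(=O)[nH]2)cc1`: in this assay compound 2 gives 13.3%.
Compound 3 `CCCCc1nc(C)c(CC(=O)OC)c(=O)n1Cc1ccc(-c2ccccc2-c2noc(=O)[nH]2)cc1`: in this assay compound 3 gives 69.6%.

Compound 3 stands highest of the three numbers; both other compounds lie far below it, with steps beyond the usual scatter. Compound 4 `CC#CCOC(=O)Cc1c(C)nc(CCCC)n(Cc2ccc(-c3ccccc3-c3noc(=O)[nH]3)cc2)c1=O` differs from compound 3 in one place: prop-1-yn-1-yl in place of hydrogen on a saturated chain carbon bound to an oxygen next to a carbonyl group. The same kind of position was varied once before, in the step from compound 1 to compound 2, where a cyclohexyl group replaced the methyl group on the oxygen of the ester; that step gave a number 2.8 percentage points higher from compound 1 to compound 2 (within the scatter). The large gain in this assay came instead from the other change, a number 59.1 percentage points higher from compound 1 to compound 3 (beyond the scatter), which compound 4 shares with compound 3. The step from compound 3 to compound 4 is therefore expected to be small, with no clear direction beyond the scatter, estimated as a number 6.6 percentage points lower from compound 3 to compound 4 (within the scatter). Compound 4 is expected to give about 63% in this assay, within a range from 42% to 82%.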

Compound 4, percent of the compound remaining: 32%
Compound 4: middle estimate off by 31 percentage points, on the high side; measured number outside the range, below it.
By their numbers in this assay, from the lowest: compounds 1 and 2 (each within the scatter of the next); then compound 4; then compound 3.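

Putting (but-2-yn-1-yl)oxy in place of methoxy gives, in this assay, a number 37.6 percentage points lower from compound 3 to compound 4 (beyond the scatter), so the group on this oxygen can change the number by a large amount. Going by these compounds alone, the only earlier change at this kind of position, a number 2.8 percentage points higher from compound 1 to compound 2 (within the scatter), left the number within the scatter, but it was made in two compounds that carry isopropyl rather than methyl on the aromatic carbon and that both sit low in this assay. Nothing available here explains the fall seen with compound 4.

The compounds shown leave open whether the fall goes with the triple bond or simply with the longer chain, which a saturated butyl group on the same oxygen would help separate. On these data alone, how an amide or a carboxylic acid in place of this ester would behave also remains open.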